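Ethyl Ester to Methyl Amide at the Top of the Scale

The compounds below may be only part of what the source reports. "The series", "measured", "known", "first", "only" and "open" are said of these compounds alone.

Compound 2 `CCOC(=O)/C=C/c1ccncc1-c1ccc2c(ccn2C)c1` gives 100% in an assay on a protein complex for inhibition of CDK8/Cyclin C (Homo sapiens), with a stated time of 1 h, tested at 10 uM; a higher number here means more inhibition at the concentration tested (going by the name of the read-out), a lower number less inhibition. Compound 1 `CCOC(=O)/C=C/c1ccncc1-c1ccc2[nH]ccc2c1` gives 100% in this assay, and compound 3 `O=C(/C=C/c1ccncc1-c1ccc2ccccc2c1)N1CCOCC1` gives 99%, so all three sit at the top of the scale, within the scatter of one another. Among the compounds with values here, the only measured step, no change at the digits printed from compound 1 to compound 2 (within the scatter), concerns a methyl on an aromatic nitrogen and leaves the carbonyl untouched, so it says little about the change now in view. Compound 4 `CNC(=O)/C=C/c1ccncc1-c1ccc2c(ccn2C)c1` differs from compound 2 by methylamino in place of ethoxy on a carbonyl carbon. Compound 3 carries an amide rather than an ester at this carbonyl and still reaches 99%, which points to no step beyond the scatter. Compound 4 is therefore expected to give 98%, between 85% and 100%, an expected step of a number 2 percentage points lower from compound 2 to compound 4 (within the scatter).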

Compound 4, a percentage reported as inhibition, at one concentration (the size of the read-out at that concentration, not a potency): 99%
The estimate for compound 4 lay 1 percentage points below the measured number; measured number inside the range.
By their numbers in this assay, from the lowest: compounds 3, 4, 1 and 2 (each within the scatter of the next).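

Putting methylamino in place of ethoxy on a carbonyl carbon gives a number 1 percentage points lower from compound 2 to compound 4 (within the scatter) in this assay. Unlike the step on the aromatic nitrogen, this one changes the carbonyl group itself, and it shows that the ester is not needed to keep the read-out at the top of the scale at this one concentration. No evidence is available on why the two groups read alike.

So close to the top of the scale, one concentration cannot reveal any differences in potency among these compounds. Going by these compounds, whether a carboxylic acid at this carbonyl, or a longer chain on the amide nitrogen, would hold the read-out remains open.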